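Ethoxy to butoxy: working notes on compound 3

This account rests on a few compounds, and the source may have more. Where it says the series, first, only, none or still open, it means among the compounds named here.

Measured in a functional assay, read by spectrophotometry, with a stated time of 6 min; on this read-out higher numbers stand for weaker inhibition and lower numbers for stronger inhibition:
- compound 1 `CCCCOc1cc(OC)c(Br)cc1C(C)=O`: 34100000 nM
- compound 2 `CCOc1cc(OC)ccc1C(C)=O`: 37700000 nM

For the measured compounds named here, compound 2 stands level with compound 1, the only other measured compound, as their two values lie within the scatter of each other. Compound 3 `CCCCOc1cc(OC)ccc1C(C)=O` replaces the ethoxy of compound 2 with butoxy: ethyl in place of hydrogen on a saturated chain carbon, two bonds along the chain from an oxygen on an aromatic ring. Going by the values given here, no measured pair isolates this change. Compound 1 also carries butoxy, with an added bromine, and gives 34100000 nM in this assay, so nothing beyond the scatter is expected. The estimated change is a 1.2-fold lower number from compound 2 to compound 3 (0.07 log units; within the scatter), expected to stay within the scatter. The expected value for compound 3 is 32000000 nM, with an estimated range of 15000000 nM to 65000000 nM.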

Compound 3, half-maximal inhibitory concentration: 36300000 nM
The estimate for compound 3 lay 1.1-fold (0.05 log units) below the measured number, and the stated range covers the measured number.
By their numbers in this assay, from the lowest: compounds 1, 3 and 2 (each within the scatter of the next).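

In this assay the shared core gives a 1.0-fold lower number from compound 2 to compound 3 (0.02 log units; within the scatter) for ethoxy to butoxy, so this change, now isolated, leaves the reading level at this position. Hydrogen in place of bromo on an aromatic carbon gives a 1.1-fold higher number from compound 1 to compound 3 (0.03 log units; within the scatter) as a second isolated step, showing that the bromine on compound 1 also leaves the reading level. No evidence bears on why these readings stay level. Open, on these data alone, is whether a longer chain than butoxy would leave the reading level too. As far as these compounds go, an amine or a carboxylic acid on a saturated chain carbon, two bonds along the chain from an oxygen on an aromatic ring, also remains open.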